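The source may report more compounds than this note shows. Statements on the series, on what has been measured and on what is new or still open speak of the compounds shown alone.

Measured so far in a functional assay on the whole organism (strain Kunming) for inhibition, with Mus musculus as the target, with a stated time of 1 h, at a dose of 40 mg/kg by the oral route; a higher number here means more inhibition at the dose given (going by the name of the read-out), a lower number less inhibition:
compound 1 `COc1ccc(/C=C/C(=O)c2ccc(N3CCN(c4ccc(Cl)c(Cl)c4)CC3)cc2)cc1OC`, 63.5%
compound 2 `COc1ccc(/C=C/C(=O)c2ccc(N3CCN(c4ccc(C)cc4C)CC3)cc2)cc1OC`, 48.5%
compound 3 `O=C(/C=C/c1ccccc1)c1ccc(N2CCN(S(=O)(=O)c3ccc(Br)cc3)CC2)cc1`, 47.4%

Compound 3 stands lowest of the three numbers; compound 2 lies within the scatter of it, while compound 1 lies beyond the scatter above it. Within the data shown here, the one measured step, a number 15 percentage points lower from compound 1 to compound 2 (beyond the scatter), concerns the aryl group on the amine nitrogen in a ring and does not bear on the present change.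

Compound 4 `COc1ccc(/C=C/C(=O)c2ccc(N3CCN(S(=O)(=O)c4ccc(Br)cc4)CC3)cc2)cc1OC` differs from compound 3 in one place: 3,4-dimethoxyphenyl in place of phenyl on a double-bonded chain carbon bound to a double-bonded chain carbon. Among the measured compounds shown here, no measured pair isolates this change. Compounds 1 and 2 carry the 3,4-dimethoxyphenyl and give the higher numbers, but they also differ from compound 3 elsewhere, so only a small rise, possibly none beyond the scatter, is expected. The expected step is a number 5.6 percentage points higher from compound 3 to compound 4 (within the scatter). Compound 4 is estimated at 53%, within 40% to 66%.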

Compound 4, a percentage reported as inhibition, in the whole organism at one dose (the size of the read-out at that dose, not a potency): 75.5%
The estimate for compound 4 lay 22.5 percentage points below the measured number; the whole stated range lies below it.
By their numbers in this assay, from the lowest: compounds 3 and 2 (each within the scatter of the next); then compound 1; then compound 4.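

In this assay, the first isolated read of this position shows that 3,4-dimethoxyphenyl in place of phenyl on the double-bonded chain carbon gives a number 28.1 percentage points higher from compound 3 to compound 4 (beyond the scatter). With 3,4-dimethoxyphenyl held, (4-bromophenyl)sulfonyl on the amine nitrogen in a ring also improves on both aryl groups, with a number 27 percentage points higher from compound 2 to compound 4 (beyond the scatter) and a number 12 percentage points higher from compound 1 to compound 4 (beyond the scatter). Nothing available explains either change.

As far as these compounds go, whether a single methoxy, a hydroxy or a dimethylamino group would hold this rise remains open. So does whether the step keeps its size with an aryl group on that nitrogen.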